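A few compounds are considered here, and "the series" means these few. Any claim that something is new, unique, unknown or untested is made for them only; others in the source may bear on it.

Working notes on the selenium and sulfur imide series, read in a functional assay on HepG2 cells (Homo sapiens) for cytotoxicity, read by MTT assay, with a stated time of 72 h; on this read-out higher numbers stand for weaker inhibition of growth and lower numbers for stronger inhibition of growth.

Three compounds carry numbers. Compound 3 `C[Se]/C(=N\C(=O)c1cccs1)NC(=O)c1cccs1` gives 630 nM in this assay. Compound 1 `C[Se]/C(=N\C(=O)c1cc2ccccc2s1)NC(=O)c1cc2ccccc2s1` gives 9590 nM, and compound 2 `CS/C(=N\C(=O)c1csc([N+](=O)[O-])c1)NC(=O)c1csc([N+](=O)[O-])c1` gives 63400 nM. Compound 3 thus stands lowest of the three, its gaps to compound 1 and to compound 2 both beyond the scatter, which makes it the strongest growth inhibitor in the set so far.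

Compound 4 `O=C(/N=C(/NC(=O)c1cccs1)[Se]Cc1ccccc1)c1cccs1` has not been measured. Relative to compound 3 the change is phenyl in place of hydrogen on a saturated chain carbon bound to a selenium atom. Within the data shown here, no pair of measured compounds differs in this way, so nothing in the data fixes the size of the step. The expectation is a step of a 1.3-fold higher number from compound 3 to compound 4 (0.10 log units; within the scatter) in this assay, small enough to fall within the scatter, in either direction. Compound 4 is therefore estimated at 800 nM, with a range from 200 nM to 3200 nM.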

Compound 4, concentration for 50% growth inhibition: 34700 nM
Compound 4: middle estimate off by 43-fold (1.64 log units), on the low side; measured number outside the range, above it.
By their numbers in this assay, from the lowest: compound 3; then compound 1; then compounds 4 and 2 (each within the scatter of the next).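

On the saturated chain carbon bound to a selenium atom, methyl to benzyl is far from a neutral change: in this assay it gives a 55-fold higher number from compound 3 to compound 4 (1.74 log units; beyond the scatter) and so weakens growth inhibition beyond the scatter. Among these compounds, this is the first step read at this position, and it shows that the position bears strongly on the read-out. Nothing at hand accounts for the size of the step.

From the compounds shown here alone, whether an ethyl chain or a carboxylic acid on the same carbon would stand nearer compound 3 or compound 4 stays open. Also open, going by these compounds, is whether methyl to benzyl gives a step of this size with sulfur in place of selenium.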